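The source may hold more compounds than are shown below. What is called first, only, known or untested is meant among the compounds shown, and "the series" means these compounds.

Working notes on the hydroxyphenyl-pyridine series.

Compound 1 `Oc1cccc(-c2cc(-c3cccs3)cc(-c3ccccc3O)n2)c1` carries a 3-hydroxyphenyl group on the shared core. In a functional assay on HCT-15 cells (Homo sapiens) for cytotoxicity, read by CCK-8 assay (a higher number here means a weaker inhibitor, a lower number a stronger inhibitor), compound 1 gives only a limit, > 50000 nM, not a number. Compound 2 `Oc1ccc(-c2cc(-c3cccs3)cc(-c3ccccc3O)n2)cc1` is its 4-hydroxyphenyl counterpart, and in this assay compound 2 likewise gives only a limit, > 50000 nM. The change between them is 4-hydroxyphenyl in place of 3-hydroxyphenyl on an aromatic carbon, and the step it made, a step that the two limits leave unreadable from compound 1 to compound 2, cannot be sized because of the limit of > 50000 nM in this assay, at which 2 of the 3 values shown sit.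

Compound 3 `Oc1cccc(-c2cc(-c3ccsc3)cc(-c3cccc(O)c3)n2)c1` differs from compound 1 in the core itself; the difference between the two cores is not broken down here. In this assay, within the data shown here, compound 3 gives 1630 nM, the only number in the set so far.

Compound 4 `Oc1ccc(-c2cc(-c3ccsc3)cc(-c3cccc(O)c3)n2)cc1` is to be measured. It differs from compound 3 by 4-hydroxyphenyl in place of 3-hydroxyphenyl on an aromatic carbon. This is the same kind of change as that from compound 1 to compound 2, though not the same: in compound 1 the place is meta to a 2-hydroxyphenyl group and meta to a thiophen-2-yl group, whereas in compound 3 it is meta to a 3-hydroxyphenyl group and meta to a thiophen-3-yl group. Since the earlier step is unreadable, the expectation for compound 4 rests on compound 3 alone, and the step from it is estimated at a 1.5-fold higher number from compound 3 to compound 4 (0.19 log units; within the scatter), within scatter. Compound 4 is therefore expected to give about 2500 nM, estimated between 800 nM and 8000 nM.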

Compound 4, half-maximal inhibitory concentration: 1180 nM
Compound 4: middle estimate off by 2.1-fold (0.33 log units), on the high side, and the stated range covers the measured number.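

On the core of compound 3, the change from 3-hydroxyphenyl to 4-hydroxyphenyl gives a 1.4-fold lower number from compound 3 to compound 4 (0.14 log units; within the scatter) in this assay, so on this core the two placements of the hydroxyl group cannot be told apart from the usual spread of repeated measurements. The same change on the core of compound 1 cannot be sized, because compound 1 and compound 2 both give limits and not numbers: the limit of > 50000 nM in this assay, at which 2 of the 4 values shown sit. That leaves one readable step and nothing to set it against, so the pair shows what the change does on one core only and does not show whether that result carries over to the other core.

The compounds shown leave open how the thiophen-3-yl group and the thiophen-2-yl group compare on an otherwise unchanged core, since no pair here differs in that one place alone. Also open, on these data alone, is what this assay would read on the core of compound 3 if the hydroxyl group on the 4-hydroxyphenyl ring gave way to a methoxy group, an amine or a carboxylic acid.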